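Azepan-1-yl in Place of Propyl on the Amide-type Nitrogen

The source may report more compounds than this note shows. Statements on the series, on what has been measured and on what is new or still open speak of the compounds shown alone.

Three compounds sharing the core of compound 1 `COc1ccc(Cl)cc1C(=O)NCC1CCN(S(=O)(=O)NC(=O)NC[C@@H]2C[C@@H]3C=C[C@@H]2C3)CC1` were tested in a functional assay on the whole organism (blood) with Rattus norvegicus as the target, with stated times of 24 h and 1 h, at a dose of 5 mg/kg by the intraperitoneal route; on this read-out lower numbers stand for a weaker effect and higher numbers for a stronger effect at the one dose given. Compound 1 gives 15%. Compound 2 `CCCCCCNC(=O)NS(=O)(=O)N1CCC(CNC(=O)c2cc(Cl)ccc2OC)CC1` gives 17%, and the step of a number 2 percentage points higher from compound 1 to compound 2 (within the scatter) is within the scatter. Compound 3 `CCCNC(=O)NS(=O)(=O)N1CCC(CCNC(=O)c2cc(Cl)ccc2OC)CC1` gives 11%; its gaps to compound 1 and to compound 2 both fall within the scatter, so the three readings cannot be told apart. Compound 4 `COc1ccc(Cl)cc1C(=O)NCCC1CCN(S(=O)(=O)NC(=O)NN2CCCCCC2)CC1` differs from compound 3 by azepan-1-yl in place of propyl on an amide-type nitrogen. Among the measured compounds shown here, the only measured step that bears on this, an exchange of groups on a saturated chain carbon bound to an amide-type nitrogen, was a number 2 percentage points higher from compound 1 to compound 2 (within the scatter), inside the scatter. A step no larger than the scatter is therefore expected, a number 3 percentage points higher from compound 3 to compound 4 (within the scatter). Compound 4 is estimated at 14%, between 4% and 28%.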

Compound 4, a percentage reported as activity, at one dose (the size of the read-out at that dose, not a potency): 36%
For compound 4 the middle estimate is 22 percentage points below the measured one, and the stated range ends below it.
By their numbers in this assay, from the lowest: compounds 3, 1 and 2 (each within the scatter of the next); then compound 4.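

In this assay, among the compounds shown here, azepan-1-yl in place of propyl on an amide-type nitrogen gives a number 25 percentage points higher from compound 3 to compound 4 (beyond the scatter) and so provides the first step that lies beyond the scatter. The result shows that the readout can respond to a change on this amide-type nitrogen, whose other neighbour is the carbonyl carbon. No measurement available here accounts for this step. On these data alone, it remains open whether the step goes with the ring, its nitrogen or the size of azepan-1-yl. Piperidin-1-yl, cyclohexyl or a hexyl chain in the same place would help to separate these possibilities.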